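This account rests on a few compounds, and the source may have more. Where it says the series, first, only, none or still open, it means among the compounds named here.

In a functional assay on CCRF-CEM cells (Homo sapiens) for cytotoxicity, read by MTT assay, with a stated time of 72 h; a lower number here means a stronger inhibitor, a higher number a weaker inhibitor:
- compound 1 `CCCCCCCCCCCC(=O)c1cc(O)c(O)c(O)c1`: 31800 nM
- compound 2 `CCCCCCCCCCCCC(=O)c1cc(O)c(O)c(O)c1`: 22000 nM
- compound 3 `CCCCCCCCCCCCCCC(=O)c1cc(O)c(O)c(O)c1`: not yet measured

Among the measured compounds shown here, compound 2 stands within the scatter of compound 1, the only other measured compound, so these two values set no order. Compound 3 carries ethyl in place of hydrogen on a saturated chain carbon, ten or more bonds along the chain from a carbonyl carbon, which is ethyl in place of hydrogen on a saturated chain carbon, ten or more bonds along the chain from a carbonyl carbon.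

For the measured compounds named here, one measured step bears on this change: a 1.4-fold lower number from compound 1 to compound 2 (0.16 log units; within the scatter), with methyl in place of hydrogen at the same kind of place. That step stays within the scatter, and a single step establishes no trend. No clear shift is therefore expected in this assay, and any drift is tentatively expected toward a lower number.

The expected step is a 1.4-fold lower number from compound 2 to compound 3 (0.14 log units; within the scatter).

For compound 3 the estimated value is 16000 nM, with an expected range of 6000 nM to 40000 nM.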

Compound 3, half-maximal inhibitory concentration: 28600 nM
Compound 3: the middle estimate sits 1.8-fold (0.25 log units) below what was measured; the measured number falls inside the stated range.
By their numbers in this assay, from the lowest: compounds 2, 3 and 1 (each within the scatter of the next).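

In this assay, ethyl in place of hydrogen on a saturated chain carbon, ten or more bonds along the chain from a carbonyl carbon, gives a 1.3-fold higher number from compound 2 to compound 3 (0.11 log units; within the scatter), and propyl at the same kind of place gives a 1.1-fold lower number from compound 1 to compound 3 (0.05 log units; within the scatter). Among the compounds shown here, the single methyl step could not show a direction, and these two new steps show none either: hydrogen, methyl, ethyl and propyl at this place all leave the number within the scatter, so the three compounds set no order. No measured evidence is available to account for this flat result.

From the compounds shown here alone, whether a longer chain would give a step beyond the scatter remains open. So does the effect of an amine or a carboxylic acid at this place on the number in this assay.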